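The compounds below may be only part of what the source reports. "The series", "measured", "known", "first", "only" and "open" are said of these compounds alone.

Compound 1, `CC(C(=O)NCc1ccc(Br)cc1)c1ccc(NS(C)(=O)=O)c(F)c1`: in a functional assay on CHO cells for antagonist activity at transient receptor potential cation channel subfamily V member 1 (Rattus norvegicus) (a higher number here means a weaker inhibitor, a lower number a stronger inhibitor), compound 1 gives 250 nM.
Compound 2, `CC(C)c1ccc(CNC(=O)C(C)c2ccc(NS(C)(=O)=O)c(F)c2)cc1`: in this assay compound 2 gives 144 nM.

For the measured compounds named here, compound 2 holds the smaller of the two numbers, yet the only measured step, a 1.7-fold lower number from compound 1 to compound 2 (0.24 log units; within the scatter), sits within the scatter, so the two compounds cannot really be told apart. Compound 3, `CC(C(=O)NCc1ccc(C2CCCC2)cc1)c1ccc(NS(C)(=O)=O)c(F)c1`, differs from compound 2 by cyclopentyl in place of isopropyl on an aromatic carbon. Going by the values given here, the one step touching this place, a 1.7-fold lower number from compound 1 to compound 2 (0.24 log units; within the scatter), was small, and nothing else measured bears on the change, so no movement beyond the scatter is expected in this assay. Compound 3 is therefore expected to give about 110 nM, between 40 nM and 300 nM, an estimated step of a 1.3-fold lower number from compound 2 to compound 3 (0.12 log units; within the scatter).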

Compound 3, inhibition constant: 20.8 nM
Estimate against measurement, compound 3: 5.3-fold (0.72 log units) above, and the stated range ends above it.
By their numbers in this assay, from the lowest: compound 3; then compounds 2 and 1 (each within the scatter of the next).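

Cyclopentyl in place of isopropyl gives a 6.9-fold lower number from compound 2 to compound 3 (0.84 log units; beyond the scatter) and cyclopentyl in place of bromo gives a 12-fold lower number from compound 1 to compound 3 (1.08 log units; beyond the scatter) on this aromatic carbon, para to a large group, so in this assay the group here clearly matters. The earlier step between bromo and isopropyl, too small to read, therefore did not mean that this position tolerates any change without effect. Nothing available explains why the cyclopentyl ring gives the lower number.

Going by these compounds, it remains open whether the ring itself or simply the larger count of carbons matters. Cyclobutyl, cyclohexyl or phenyl here could help separate those two readings, and an amine would test a group that is not carbon only.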